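The compounds below may be only part of what the source reports. "The series", "measured", "known", "first", "only" and "open" are said of these compounds alone.

Three compounds were measured in a functional assay on MOLT-4 cells (Homo sapiens) for antiproliferative activity, read by MTT assay, with a stated time of 72 h; a lower number here means a stronger inhibitor, a higher number a weaker inhibitor:

Compound 1 `O=C1NC(=O)/C(=C/C2=Cc3cc(Br)ccc3OC2)S1` gives 54700 nM
Compound 2 `O=C1NC(=S)S/C1=C\C1=Cc2cc(Br)ccc2OC1` gives 38200 nM
Compound 3 `CC1Oc2ccc(Br)cc2C=C1/C=C1\SC(=O)NC1=O` gives 64500 nM

All three numbers are high, and the gaps between them lie within the scatter of repeated measurements, so none of the three can be called stronger or weaker than another. Compound 3 is made from compound 1 by a single change, (methyl in place of hydrogen on a saturated ring carbon), and this change brought a 1.2-fold higher number from compound 1 to compound 3 (0.07 log units; within the scatter). Compound 2 is built on a different core from compound 1; the difference between the two cores is not broken down here, and the two values show only that they lie close together.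

Compound 4 `CC1Oc2ccc(Br)cc2C=C1/C=C1\SC(=S)NC1=O` has not yet been measured. It is made from compound 2 by methyl in place of hydrogen on a saturated ring carbon, and the place of this change is described in the same words as for compound 1 and compound 3, so it is the same change on the other core. Among the compounds with values here, the expected step is a 1.2-fold higher number from compound 2 to compound 4 (0.07 log units; within the scatter), and this expectation rests on compound 1 and compound 3 because a 1.2-fold higher number from compound 1 to compound 3 (0.07 log units; within the scatter) is the only measured instance of this change. For compound 4 the estimate in this assay is 45000 nM, expected to fall between 20000 nM and 100000 nM.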

Compound 4, half-maximal inhibitory concentration: 20500 nM
Estimate against measurement, compound 4: 2.2-fold (0.34 log units) above; the range from low to high includes it.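

In this assay, methyl in place of hydrogen on a saturated ring carbon gave a 1.9-fold lower number from compound 2 to compound 4 (0.27 log units; within the scatter). Set beside the earlier case, the change looks no different on the two cores: the same change on two cores in this assay, a 1.2-fold higher number (0.07 log units; within the scatter) from compound 1 to compound 3 and a 1.9-fold lower number (0.27 log units; within the scatter) from compound 2 to compound 4, 2.2-fold (0.34 log units) apart, within the scatter of two such steps. The two results therefore give no sign that the choice of core alters what this methyl does, but with a single pair on each core and both steps inside the scatter, they do not show that the methyl has a real effect on either core, or that the match would hold on a further core.

The compounds shown carry only hydrogen or methyl at this ring carbon, so it remains open what an ethyl group, a longer chain or a carboxylic acid would do there. From the compounds shown here alone, it also remains open whether any such group would move the number beyond the scatter on either core, and whether the two cores would then still respond alike.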